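The source may hold more compounds than are shown below. What is called first, only, known or untested is meant among the compounds shown, and "the series" means these compounds.

Of the compounds shown here, three that share one core have been tested in a functional assay on NCI-H460 cells (Homo sapiens) for cytotoxicity, read by MTT assay, with a stated time of 68 h; on this read-out lower numbers stand for stronger inhibition and higher numbers for weaker inhibition: compound 1 `O=C(Nc1cccc(-c2ccccn2)c1)C(Cl)Cl`, compound 2 `COc1ccc(-c2cccc(NC(=O)C(Cl)Cl)c2)cc1` and compound 3 `O=C(Nc1cccc(-c2cccc(Cl)c2)c1)C(Cl)Cl`. For compound 1, the assay reports only a limit, > 50000 nM. Compound 3 likewise gives only a limit, > 50000 nM. Compound 2 is the only one of the three with an actual number, 43300 nM. Compound 3 therefore has no exact position in the set: it sits at the limit of > 50000 nM in this assay, at which 2 of the 3 values shown sit.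

The next compound to be tested is compound 4 `O=C(Nc1cccc(-c2ccccc2)c1)C(Cl)Cl`. It differs from compound 3 in a single place: hydrogen in place of chloro on an aromatic carbon. In words, hydrogen stands in place of chloro on an aromatic carbon, meta to a large group.

Among the measured compounds shown here, no measured pair in this small set differs in only one place, so no direct guide exists for the size of this change. For the measured compounds named here, the only number to lean on is that of compound 2, at 43300 nM. A change beyond the usual scatter, in either direction, is therefore not expected in this assay. The expected step, an at least 1.1-fold lower number from compound 3 to compound 4 (0.04 log units; that floor lies within the scatter), is estimated to be small. For compound 4 the estimate is 45000 nM, with an expected range from 20000 nM to 90000 nM.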

Compound 4, half-maximal inhibitory concentration: 20200 nM
Beside the measured number, compound 4's estimate is 2.2-fold (0.35 log units) above it; the range from low to high includes it.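

In this assay, among the compounds shown here, taking the chloro off its aromatic carbon and leaving hydrogen gives the first clear step at this position: an at least 2.4-fold lower number from compound 3 to compound 4 (0.39 log units; beyond the scatter), so the position responds to what sits on it. Two further changes point the same way, with hydrogen in place of methoxy giving a 2.1-fold lower number from compound 2 to compound 4 (0.33 log units; beyond the scatter) and phenyl in place of pyridin-2-yl giving an at least 2.4-fold lower number from compound 1 to compound 4 (0.39 log units; beyond the scatter), which leaves compound 4 with the lowest number of the four, and each of its three steps lies beyond the scatter. Two of these steps start from a limit rather than from a true number, so their full size remains unknown: the limit of > 50000 nM in this assay, at which 2 of the 4 values shown sit.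

Chloro and methoxy are the only groups shown in place of hydrogen on this ring, and both give higher numbers than hydrogen, so it remains open whether any group on this ring can bring the number below that of compound 4. An amine or a carboxylic acid on the same ring could move the number either way, and the compounds shown do not tell why losing the chloro lowers it.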